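The compounds below may be only part of what the source reports. "The series", "measured", "known", "first", "only" and "open" are said of these compounds alone.

Compounds measured in a functional assay on MDA-MB-231 cells (Homo sapiens) for inhibition, read by MTT assay and WST assay, with a stated time of 72 h, tested at 10 uM; on this read-out higher numbers stand for more inhibition of growth at the one concentration tested and lower numbers for less inhibition of growth:
compound 1 `O=C(Nc1ccc(Cl)cc1)Nc1ccc(Oc2ccc(-c3nccs3)cc2)cc1` gives 32.5%;
compound 2 `O=C(Nc1ccc(Cl)cc1)Nc1ccc(Oc2ccc(-c3ncc[nH]3)cc2)cc1` gives 47.6%.

Going by the values given here, compound 2 stands highest of the two numbers; the only measured step, a number 15.1 percentage points higher from compound 1 to compound 2 (beyond the scatter), separates it from compound 1. Compound 3 `O=C(Nc1ccc(Oc2ccc(-c3ncc[nH]3)cc2)cc1)Nc1cc(Br)cc(C(F)(F)F)c1` carries the change (3-bromo-5-(trifluoromethyl)phenyl in place of 4-chlorophenyl on an amide-type nitrogen). Among the compounds with values here, no measured step touches this part of the molecule, since the single step known alters the heteroaryl group on the other side, so nothing here predicts the size or direction of the change; compound 3 is therefore expected to land near compound 2, with a step of a number 4.4 percentage points higher from compound 2 to compound 3 (within the scatter) and wide uncertainty. The estimated value of compound 3 in this assay is 52%, ranging from 28% to 78%.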

Compound 3, percent growth inhibition at one concentration: -13.6%
Beside the measured number, compound 3's estimate is 65.6 percentage points above it, and the stated range ends above it.
By their numbers in this assay, from the lowest: compound 3; then compound 1; then compound 2.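

In this assay, the group on the amide-type nitrogen proves a sensitive part of the molecule: 3-bromo-5-(trifluoromethyl)phenyl in place of 4-chlorophenyl gives a number 61.2 percentage points lower from compound 2 to compound 3 (beyond the scatter). This step is larger than the earlier heteroaryl change, which gave a number 15.1 percentage points higher from compound 1 to compound 2 (beyond the scatter). No measurement at hand accounts for the drop.

The compounds shown leave open whether the bromo group or the trifluoromethyl group alone would bring such a drop. They also leave open how a phenyl ring carrying a methoxy group or an amine would read on this nitrogen.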